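From trifluoromethyl to iodo in compound 2

The source may hold more compounds than are shown below. What is called first, only, known or untested is meant among the compounds shown, and "the series" means these compounds.

- Compound 1 `Cc1cc(F)cc(Nc2cc(NC(=O)Nc3c(Cl)cccc3Cl)ncn2)c1` gives 3780 nM
- Compound 2 `COc1cc(NC(=O)Nc2cc(Nc3cc(C(F)(F)F)ccc3OC)ncn2)cc(OC)c1` gives 4450 nM
- Compound 3 `COc1cc(Nc2cc(NC(=O)Nc3c(Cl)cccc3Cl)ncn2)cc(OC)c1` gives 10500 nM

Among the compounds with values here, all three numbers come from a functional assay on NCI-H520 cells (Homo sapiens) for antiproliferative activity, read by MTT assay, with a stated time of 48 h (on this read-out lower numbers stand for stronger inhibition and higher numbers for weaker inhibition), and are the only measurements so far. Compound 2 cannot be told apart from compound 1, while compound 3 shows a higher number than compound 2, beyond the scatter, and so weaker inhibition.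

Compound 4 `COc1cc(NC(=O)Nc2cc(Nc3cc(I)ccc3OC)ncn2)cc(OC)c1` is still unmeasured. Its change from compound 2 is iodo in place of trifluoromethyl on an aromatic carbon with iodo in place of trifluoromethyl on an aromatic carbon, para to a methoxy group. Within the data shown here, no measured pair shows this swap, so the guide is thin. In this assay a step within the scatter is expected, with neither direction favoured. The estimate gives a 1.1-fold lower number from compound 2 to compound 4 (0.05 log units; within the scatter) as the expected change. Compound 4 is estimated at 4000 nM with an expected range from 1500 nM to 10000 nM for repeated measurements.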

Compound 4, half-maximal inhibitory concentration: 9870 nM
The estimate for compound 4 lay 2.5-fold (0.39 log units) below the measured number; measured number inside the range.
By their numbers in this assay, from the lowest: compounds 1 and 2 (each within the scatter of the next); then compounds 4 and 3 (each within the scatter of the next).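

In this assay, iodo in place of trifluoromethyl, para to a methoxy group, brings a 2.2-fold higher number from compound 2 to compound 4 (0.35 log units; beyond the scatter) and so weaker inhibition. Within the data shown here, this is the first comparison here of compounds that differ in one place, and it shows that activity responds to the group at this position. It rests on a single pair, and nothing at hand explains the direction of the step. On these data alone, whether chloro, an amine or a carboxylic acid at this position would match trifluoromethyl or iodo remains open. As far as these compounds go, whether the same swap would give a similar step in another compound also remains open.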